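The source may hold more compounds than are shown below. What is called first, only, known or untested is meant among the compounds shown, and "the series" means these compounds.

The measured compounds: compound 1 `CCC(CC)(c1ccc(OCC(=O)C(C)(C)CCCCc2ccccc2)c(C)c1)c1ccc(OC[C@@H](O)CO)c(C)c1`, compound 2 `CCC(CC)(c1ccc(OCC(=O)C(C)(C)Cc2ccc3ccccc3c2)c(C)c1)c1ccc(OC[C@@H](O)CO)c(C)c1`, and compound 3 `CCC(CC)(c1ccc(OCC(O)C(C)(C)CCCCc2ccccc2)c(C)c1)c1ccc(OC[C@@H](O)CO)c(C)c1`.

In an assay on HL-60 cells for activation of vitamin D3 receptor (Homo sapiens) (a higher number here means that more compound is needed for the effect, a lower number that less compound is needed), compound 1 gives > 30000 nM, which is a limit of the assay and not a number. Compound 2 likewise reaches only a limit, > 30000 nM. Compound 3 also stops at a limit, > 30000 nM. The difference between the cores of compound 1 and compound 3 is not broken down here. The change naphthalen-2-yl in place of 3-phenylpropyl on a saturated chain carbon, two bonds along the chain from a carbonyl carbon gives a step that the two limits leave unreadable from compound 1 to compound 2, since all three values sit at the limit of > 30000 nM in this assay, at which 3 of the 3 values shown sit.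

Compound 4 `CCC(CC)(c1ccc(OCC(O)C(C)(C)Cc2ccc3ccccc3c2)c(C)c1)c1ccc(OC[C@@H](O)CO)c(C)c1` has not been measured. It carries the same kind of change, (naphthalen-2-yl in place of 3-phenylpropyl on a saturated chain carbon, three bonds along the chain from an oxygen on a saturated carbon), differing only in its surroundings: two bonds along the chain from a carbonyl carbon in the earlier pair, three bonds along the chain from an oxygen on a saturated carbon here. Because compound 3 gives only the limit > 30000 nM, no readable step is available to build on. Compound 4 is therefore expected to remain at a limit, with an estimate of 50000 nM. The step from compound 3 expected by this estimate is a step that the limit leaves unreadable from compound 3 to compound 4.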

Compound 4, half-maximal effective concentration: > 30000 nM
Compound 4: only a limit was reported; the forecaster's own chance of this, stated with the estimate: 90%; the middle value does not contradict the limit.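

The step between compound 3 and compound 4 cannot be read, since both stop at the same limit: the limit of > 30000 nM in this assay, at which 4 of the 4 values shown sit.

The compounds shown leave open what value any of them would reach in this assay, and whether naphthalen-2-yl in place of 3-phenylpropyl changes it at all.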